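A few compounds are considered here, and "the series" means these few. Any claim that something is new, unique, unknown or untested is made for them only; others in the source may bear on it.

Measured compounds:
compound 1, `COc1ccc2[nH]c(-c3ccccc3)c(C=C(C#N)C#N)c2c1`: 2300 nM
compound 2, `CC(=O)/C(=C\c1c(-c2ccccc2)[nH]c2ccccc12)S(=O)(=O)c1ccccc1`: 1400 nM

In a functional assay on T47D cells (Homo sapiens) for inhibition, read by sulforhodamine B assay, with a stated time of 48 h (a lower number here means a stronger inhibitor of growth, a higher number a weaker inhibitor of growth), compound 2 gives 1400 nM, the smaller of the two numbers shown. Its nearest neighbour is compound 1, which in this assay gives 2300 nM; the gap between the two lies within the usual scatter, so neither compound can be called the stronger growth inhibitor on this evidence.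

Compound 3, `O=C(/C(=C\c1c(-c2ccccc2)[nH]c2ccccc12)S(=O)(=O)c1ccccc1)c1ccccc1`, carries one change against compound 2: phenyl in place of methyl on a carbonyl carbon. For the measured compounds named here, no pair of measured compounds shows this change, so there is no measured step to lean on. Going by the values given here, with only two compounds in hand, both within the scatter of each other, the expectation for this change is a small step at most, possibly none beyond the scatter.

Compound 3 is therefore expected to give 1000 nM in this assay, with a range from 400 nM to 3000 nM. The estimated step of a 1.4-fold lower number from compound 2 to compound 3 (0.15 log units; within the scatter) is expected to stay within the usual scatter.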

Compound 3, concentration for 50% growth inhibition: 3400 nM
The estimate for compound 3 lay 3.4-fold (0.53 log units) below the measured number; the measured number lies above the stated range.
By their numbers in this assay, from the lowest: compounds 2, 1 and 3 (each within the scatter of the next, the first and the last beyond it).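

For the compounds shown here, the change from acetyl to benzoyl gives a 2.4-fold higher number from compound 2 to compound 3 (0.39 log units; beyond the scatter) in this assay and is the first reading at this position, a modest loss of growth inhibition. It shows that the group on this carbonyl carbon matters: phenyl in place of methyl weakens growth inhibition rather than leaving it unchanged, which compound 1 and compound 2, differing in more than one place, could not show. Nothing measured here explains this step.

On these data alone, one step gives only two points at this position, so it remains open whether the loss grows steadily with the group or is particular to phenyl. Where a longer chain such as ethyl, an amine or a methoxy group on this carbonyl carbon would fall relative to compound 2 also remains unknown.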